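Swapping Fluoro for Tert-Butyl: Estimating Compound 4

The source may report more compounds than this note shows. Statements on the series, on what has been measured and on what is new or still open speak of the compounds shown alone.

Three close relatives share one core. Compound 1 `CCOC(=O)c1sc(-c2cccc(NC(=O)c3ccc(C(C)(C)C)cc3)c2)nc1Nc1ccc(N2CCN(C)CC2)cc1` carries a tert-butyl group, but in a functional assay on Ramos cells (Homo sapiens) for antiproliferative activity, read by CCK-8 assay, with a stated time of 72 h (a higher number here means a weaker inhibitor, a lower number a stronger inhibitor), compound 1 shows "not determined" (no result reported). Compound 2 `CN1CCN(c2ccc(Nc3nc(-c4cccc(NC(=O)c5ccc(C(F)(F)F)cc5)c4)sc3C(N)=O)cc2)CC1` bears a trifluoromethyl group, and in this assay compound 2 gives 1580 nM. Compound 3 `CN1CCN(c2ccc(Nc3nc(-c4cccc(NC(=O)c5ccc(F)cc5)c4)sc3C(N)=O)cc2)CC1` bears a fluoro group instead, and in this assay compound 3 gives 1420 nM, the lower of the two numbers, though the step of a 1.1-fold lower number from compound 2 to compound 3 (0.05 log units; within the scatter) stays within the scatter, so the two cannot be ranked.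

Compound 4 `CN1CCN(c2ccc(Nc3nc(-c4cccc(NC(=O)c5ccc(C(C)(C)C)cc5)c4)sc3C(N)=O)cc2)CC1` is compound 3 with one change: tert-butyl in place of fluoro on an aromatic carbon, placed on an aromatic carbon of a six-membered aromatic ring of carbon only, para to a large group. Among the compounds with values here, the only measured step at this place is a 1.1-fold lower number from compound 2 to compound 3 (0.05 log units; within the scatter), which shows that exchanging one group for another there left the number essentially unchanged. Within the data shown here, no measured step covers tert-butyl itself. The expected step of a 1.0-fold lower number from compound 3 to compound 4 (0.01 log units; within the scatter) is therefore small, in no firm direction. Compound 4 is estimated at 1400 nM, with a range from 500 nM to 4000 nM.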

Compound 4, half-maximal inhibitory concentration: 8600 nM
Estimate against measurement, compound 4: 6.1-fold (0.79 log units) below, and the stated range ends below it.
By their numbers in this assay, from the lowest: compounds 3 and 2 (each within the scatter of the next); then compound 4.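

At this position on the six-membered aromatic ring of carbon only, the group does matter in this assay: tert-butyl gives a 6.1-fold higher number from compound 3 to compound 4 (0.78 log units; beyond the scatter) and also a 5.4-fold higher number from compound 2 to compound 4 (0.74 log units; beyond the scatter), both beyond the scatter and both toward a weaker inhibitor. The earlier pair, fluoro and trifluoromethyl, could not be told apart, so the flat picture they gave holds for those two groups only and does not extend to tert-butyl. Nothing available here explains why this one exchange moves the number when the other does not.

The three numbers cannot show whether a methyl or isopropyl group would behave like fluoro or like tert-butyl. Going by these compounds, how an amine or a carboxylic acid at the same place would compare also remains open.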